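The source may hold more compounds than are shown below. What is called first, only, known or untested is meant among the compounds shown, and "the series" means these compounds.

Among the compounds with values here, compound 3 `CC1=CCC[C@H]2[C@](C)(CC3=CC(=O)C=C(NCC(=O)O)C3=O)[C@@H](C)CC[C@]12C` stands at the top of the two numbers so far: in a functional assay on A549 cells (Homo sapiens) for cytotoxicity, read by MTT assay, with a stated time of 72 h (a higher number here means a weaker inhibitor, a lower number a stronger inhibitor), compound 3 gives 46700 nM, and the nearest value belongs to compound 1 `CC1=CCC[C@H]2[C@](C)(CC3=CC(=O)C=C(N[C@@H](C(=O)O)C(C)C)C3=O)[C@@H](C)CC[C@]12C`, which in this assay gives 23800 nM, so that a 2.0-fold higher number from compound 1 to compound 3 (0.29 log units; within the scatter). Compound 2 `CSCC[C@H](NC1=CC(=O)C=C(C(C)(C)C)C1=O)C(=O)O` in this assay reports only a limit, > 200000 nM. Compound 4 `CC1=CCC[C@H]2[C@](C)(CC3=CC(=O)C=CC3=O)[C@@H](C)CC[C@]12C` differs from compound 3 by hydrogen in place of (carboxymethyl)amino on a double-bonded ring carbon. Within the data shown here, no measured step removes the amino acid entirely; the one step on record, a 2.0-fold higher number from compound 1 to compound 3 (0.29 log units; within the scatter), only changed its side chain. The change to compound 4 is larger, so an expectation beyond the scatter is possible but unsupported either way, and compound 4 is expected to give 35000 nM in this assay, within 8000 nM to 160000 nM, meaning a 1.3-fold lower number from compound 3 to compound 4 (0.13 log units; within the scatter).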

Compound 4, half-maximal inhibitory concentration: 30000 nM
The estimate for compound 4 lay 1.2-fold (0.07 log units) above the measured number; the measured number falls inside the stated range.
By their numbers in this assay, from the lowest: compounds 1, 4 and 3 (each within the scatter of the next). At a limit, above all of these: compound 2.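

In this assay, replacing the whole amino acid group on this double-bonded ring carbon with hydrogen leaves the number within the scatter: a 1.6-fold lower number from compound 3 to compound 4 (0.19 log units; within the scatter), and a 1.3-fold higher number from compound 1 to compound 4 (0.10 log units; within the scatter). Among compounds 1, 3 and 4, which share the core, neither amino acid group therefore sets the number apart from plain hydrogen. Nothing measured here gives a reason for this.

On these data alone, it remains open whether a simple amine or a carboxylic acid set directly on this ring carbon would move the number beyond the scatter. The same holds for a longer chain ending in an amide.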